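The source may hold more compounds than are shown below. What is called first, only, known or untested is meant among the compounds shown, and "the series" means these compounds.

Compound 1 `Cc1ccccc1-n1cc(COc2cccc(NC(=O)Nc3ccc(Cl)c(C(F)(F)F)c3)c2)nn1` and compound 2 `Cc1cccc(-n2cc(COc3cccc(NC(=O)Nc4ccc(Cl)c(C(F)(F)F)c4)c3)nn2)c1` share a core and differ only in the aryl group on the aromatic nitrogen. Within the data shown here, in a functional assay on HepG2 cells (Homo sapiens) for inhibition, read by MTT assay, with a stated time of 72 h (on this read-out higher numbers stand for weaker inhibition and lower numbers for stronger inhibition), compound 1 gives 3440 nM, while compound 2 gives 7270 nM, which is the highest of the two numbers recorded; the step of a 2.1-fold higher number from compound 1 to compound 2 (0.32 log units; beyond the scatter) sets the only measured comparison available. Compound 3 `Cc1ccc(-n2cc(COc3cccc(NC(=O)Nc4ccc(Cl)c(C(F)(F)F)c4)c3)nn2)cc1` is the next member of this series and has not yet been measured. It differs from compound 2 in one place: 4-methylphenyl in place of 3-methylphenyl on an aromatic nitrogen. The step from compound 1 to compound 2 bears on this change only loosely, since it shifts the methyl from one position to another on the same phenyl ring and produced a modest rise that was beyond the scatter. Nothing measured shows what a further shift of the methyl does, and the two compounds at hand give no trend that could be carried forward. Compound 3 is therefore expected to sit close to compound 2, with a 1.0-fold lower number from compound 2 to compound 3 (0.02 log units; within the scatter) within or only slightly beyond the scatter in either direction. The estimate for compound 3 in this assay is 7000 nM, within a range from 3000 nM to 16000 nM.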

Compound 3, half-maximal inhibitory concentration: 5430 nM
Beside the measured number, compound 3's estimate is 1.3-fold (0.11 log units) above it; the range from low to high includes it.
By their numbers in this assay, from the lowest: compounds 1, 3 and 2 (each within the scatter of the next, the first and the last beyond it).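

In this assay, putting 4-methylphenyl in place of 3-methylphenyl on the aromatic nitrogen gives a 1.3-fold lower number from compound 2 to compound 3 (0.13 log units; within the scatter) and, set against the 2-methylphenyl of compound 1, the same group gives a 1.6-fold higher number from compound 1 to compound 3 (0.20 log units; within the scatter), so compound 3 lies within the scatter of both other compounds. The earlier step, a 2.1-fold higher number from compound 1 to compound 2 (0.32 log units; beyond the scatter), therefore remains the only one beyond the scatter among these three methylphenyl compounds, and the new compound does not turn it into a steady trend along the ring: moving the methyl group around this phenyl ring changes the number only modestly across the compounds shown. No measurement at hand accounts for these small differences.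

The compounds shown leave open what this position does when the methyl group is replaced, for example by a methoxy group, a chlorine atom, a longer chain such as ethyl, or an amine, or when the phenyl ring carries no substituent at all. They also leave open whether a carboxylic acid on this ring, or a larger group at the same aromatic nitrogen, would move the number well beyond the modest range seen with the three methylphenyl groups.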